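A few compounds are considered here, and "the series" means these few. Any claim that something is new, unique, unknown or untested is made for them only; others in the source may bear on it.

Compound 1 `COc1ccc2[nH]c(-c3cn(-c4ccccc4)nc3-c3ccc(Cl)cc3)nc2c1`: 2420 nM
Compound 2 `FC(F)(F)c1ccc2[nH]c(-c3cn(-c4ccccc4)nc3-c3ccc(Cl)cc3)nc2c1`: 3360 nM
Compound 3 `COc1ccc(-c2nn(-c3ccccc3)cc2-c2nc3cc(OC)ccc3[nH]2)cc1`: 22700 nM

Three compounds were measured in a functional assay on A549 cells (Homo sapiens) for antiproliferative activity, read by MTT assay, with a stated time of 48 h; on this read-out higher numbers stand for weaker inhibition and lower numbers for stronger inhibition. Compound 1 `COc1ccc2[nH]c(-c3cn(-c4ccccc4)nc3-c3ccc(Cl)cc3)nc2c1` gave 2420 nM, and compound 2 `FC(F)(F)c1ccc2[nH]c(-c3cn(-c4ccccc4)nc3-c3ccc(Cl)cc3)nc2c1` gave 3360 nM, a step of a 1.4-fold higher number from compound 1 to compound 2 (0.14 log units; within the scatter), the change being (trifluoromethyl in place of methoxy on an aromatic carbon). Compound 3 `COc1ccc(-c2nn(-c3ccccc3)cc2-c2nc3cc(OC)ccc3[nH]2)cc1` gave 22700 nM; from compound 1 this is a 9.4-fold higher number from compound 1 to compound 3 (0.97 log units; beyond the scatter), and the two cores differ by methoxy in place of chloro on an aromatic carbon.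

Compound 4 `COc1ccc(-c2nn(-c3ccccc3)cc2-c2nc3cc(C(F)(F)F)ccc3[nH]2)cc1` has not been measured. It differs from compound 3 by trifluoromethyl in place of methoxy on an aromatic carbon, the same change as from compound 1 to compound 2, at the same place. Since that earlier step was a 1.4-fold higher number from compound 1 to compound 2 (0.14 log units; within the scatter), the step from compound 3 to compound 4 is expected to be about a 1.3-fold higher number from compound 3 to compound 4 (0.12 log units; within the scatter). Compound 4 is therefore estimated at 30000 nM in this assay, between 12000 nM and 75000 nM.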

Compound 4, half-maximal inhibitory concentration: 4820 nM
Estimate against measurement, compound 4: 6.2-fold (0.79 log units) above, and the stated range ends above it.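

In this assay, trifluoromethyl in place of methoxy gave a 4.7-fold lower number from compound 3 to compound 4 (0.67 log units; beyond the scatter), so the step seen on the core of compound 1 did not carry over to the core of compound 3: the same change on two cores in this assay, a 1.4-fold higher number (0.14 log units; within the scatter) from compound 1 to compound 2 and a 4.7-fold lower number (0.67 log units; beyond the scatter) from compound 3 to compound 4, 6.5-fold (0.82 log units) apart, beyond the scatter of two such steps. Likewise, methoxy in place of chloro gave a 1.4-fold higher number from compound 2 to compound 4 (0.16 log units; within the scatter), so the size of that step also depended on the core: the same change on two cores in this assay, a 9.4-fold higher number (0.97 log units; beyond the scatter) from compound 1 to compound 3 and a 1.4-fold higher number (0.16 log units; within the scatter) from compound 2 to compound 4, 6.5-fold (0.82 log units) apart, beyond the scatter of two such steps. In these four compounds, then, the two changes do not add up independently, but this shows neither why they do not nor how either change would behave on any other core.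

The compounds shown leave open whether this holds for other groups at these two places. A nitrile or an amine at the first, or a methyl or fluorine at the second, might behave differently.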